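A few compounds are considered here, and "the series" means these few. Any claim that something is new, unique, unknown or untested is made for them only; others in the source may bear on it.

Compound 3 `CC(=O)OC[C@H]1O[C@@H](n2cc(CN3C(=O)/C(=C/C=C/c4ccccc4)c4ccccc43)nn2)[C@H](OC(C)=O)[C@@H](OC(C)=O)[C@@H]1OC(C)=O` gives the lowest of the two numbers in an ADME assay on NIH3T3 cells (Homo sapiens) for cytotoxicity, read by sulforhodamine B assay, with a stated time of 48 h (a higher number here means a weaker inhibitor, a lower number a stronger inhibitor), at 12300 nM. Its geometric isomer compound 2 `CC(=O)OC[C@H]1O[C@@H](n2cc(CN3C(=O)/C(=C\C=C\c4ccccc4)c4ccccc43)nn2)[C@H](OC(C)=O)[C@@H](OC(C)=O)[C@@H]1OC(C)=O` gives 25900 nM in this assay, and the step of a 2.1-fold lower number from compound 2 to compound 3 (0.32 log units; beyond the scatter) rests only on (the fact that compounds 2 and 3 differ only in the configuration as drawn). Compound 1 `CC(=O)OC[C@H]1O[C@@H](n2cc(Cn3cc(C(C)=O)c4ccccc43)nn2)[C@H](OC(C)=O)[C@@H](OC(C)=O)[C@@H]1OC(C)=O` reaches a limit of the assay in this assay, namely > 200000 nM, which is the limit of > 200000 nM in this assay, at which 1 of the 3 values shown sits. Compound 4 `CCC/C=C1/C(=O)N(Cc2cn([C@@H]3O[C@H](COC(C)=O)[C@@H](OC(C)=O)[C@H](OC(C)=O)[C@H]3OC(C)=O)nn2)c2ccccc21` differs from compound 3 by propyl in place of 2-phenylethenyl on a double-bonded chain carbon bound to a double-bonded ring carbon. Within the data shown here, no measured step alters the group at this place, so only the modest size of a 2.1-fold lower number from compound 2 to compound 3 (0.32 log units; beyond the scatter) and the limit reached by compound 1 guide the expectation. Compound 4 is expected to give a higher number in this assay, with the step of a 4.1-fold higher number from compound 3 to compound 4 (0.61 log units; beyond the scatter) estimated as moderate and uncertain. The estimate for compound 4 in this assay is 50000 nM, in the range 15000 nM to 200000 nM.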

Compound 4, half-maximal inhibitory concentration: > 100000 nM
Compound 4: only a limit was reported (the forecaster's own chance of this, stated with the estimate: 30%); middle value at least 2.0-fold (0.30 log units) from the limit.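

In this assay, among these compounds, the step at this place is an at least 8.1-fold higher number from compound 3 to compound 4 (0.91 log units; beyond the scatter), the first measured change of the group on a double-bonded chain carbon bound to a double-bonded ring carbon, and it exceeds the step from double-bond configuration alone, a 2.1-fold lower number from compound 2 to compound 3 (0.32 log units; beyond the scatter). The value of compound 4, > 100000 nM, is a limit of the assay. Losing 2-phenylethenyl for propyl therefore moves the number more than redrawing that double bond does. As far as these compounds go, it remains open whether the aromatic ring or the double bond of 2-phenylethenyl accounts for this, and what a 2-phenylethyl group or a longer chain such as pentyl would give here.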